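The source may hold more compounds than are shown below. What is called first, only, known or untested is meant among the compounds shown, and "the series" means these compounds.

Measured compounds:
compound 1 `CSc1nc(-c2cccc(O)c2)c2c(N)c(C(=O)NC(C)(C)C)sc2n1` — 11.2%
compound 2 `COc1cccc(-c2nc(SC)nc3sc(C(=O)NCC#N)c(N)c23)c1` — 3.6%
compound 3 `CSc1nc(-c2cccc(F)c2)c2c(N)c(C(=O)NC(C)(C)C)sc2n1` — 8.1%

All three values come from a functional assay on HEK293 cells for agonist activity at Thyrotropin receptor (Homo sapiens), read by cAMP accumulation; a higher number here means a larger maximal response, a lower number a smaller maximal response. Compound 2 gives the smallest of the three numbers, yet its gaps to compound 3 and to compound 1 are both within the scatter, so the three cannot be told apart. Compound 4 `COc1cccc(-c2nc(SC)nc3sc(C(=O)NNC(C)(C)C)c(N)c23)c1` differs from compound 2 as follows: (tert-butyl)amino in place of cyanomethyl on an amide-type nitrogen. For the measured compounds named here, no measured step changes this part of the molecule; the only measured step, a number 3.1 percentage points lower from compound 1 to compound 3 (within the scatter), concerns a ring substituent and is within the scatter. With nothing pointing either way, no step beyond the scatter is expected. Compound 4 is therefore estimated at 8%, range 2% to 16%, an expected step of a number 4.4 percentage points higher from compound 2 to compound 4 (within the scatter).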

Compound 4, largest response reached (reported as efficacy), in percent of the reference or control that the assay uses: 6.4%
Beside the measured number, compound 4's estimate is 1.6 percentage points above it; measured number inside the range.
By their numbers in this assay, from the lowest: compounds 2, 4, 3 and 1 (each within the scatter of the next).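

In this assay, (tert-butyl)amino in place of cyanomethyl on the amide-type nitrogen gives a number 2.8 percentage points higher from compound 2 to compound 4 (within the scatter). For the compounds shown here, this is the first measured change at this position, and exchanging a nitrile-bearing chain for a group with more heavy atoms and a hydrogen-bond donor leaves the response within the scatter. Nothing available explains the result. Still open, as far as these compounds go, is whether a carboxylic acid or a longer carbon chain on this nitrogen would move the maximal response beyond the scatter.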